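Hydrogen for methoxy on compound 2

This account rests on a few compounds, and the source may have more. Where it says the series, first, only, none or still open, it means among the compounds named here.

In an ADME assay on microsomes from liver (Rattus norvegicus, strain Sprague-Dawley) for metabolic stability, read by LC-MS, using NADPH, with a stated time of 30 min, tested at 3 uM (a higher number here means that more of the compound is left, a lower number that less of the compound is left), compound 1 `CN1Cc2cc(-c3ccc(-c4cncc(NS(=O)(=O)c5cccc(C(F)(F)F)c5)c4)s3)cnc2C1=O` gives 84% as its reading, and compound 2 `COc1ncc(-c2ccc(-c3cnc4c(c3)CN(C)C4=O)s2)cc1NS(=O)(=O)c1ccccc1C(F)(F)F` gives 50% as its reading, the lower of the two numbers, with a gap beyond the usual scatter. Compound 3 `CN1Cc2cc(-c3ccc(-c4cncc(NS(=O)(=O)c5ccccc5C(F)(F)F)c4)s3)cnc2C1=O` differs from compound 2 by hydrogen in place of methoxy on an aromatic carbon and is still unmeasured. Among the compounds with values here, no measured step isolates this change. Within the data shown here, with compound 1 at 84% as the only higher reading, a rise is expected. The expected step of a number 18 percentage points higher from compound 2 to compound 3 (beyond the scatter) is upward and beyond the scatter. For compound 3 the estimated value is 68% with an expected range of 50% to 86% in this assay.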

Compound 3, percent of the compound remaining in the Rattus norvegicus assay: 36%
Beside the measured number, compound 3's estimate is 32 percentage points above it; the measured number lies below the stated range.
By their numbers in the Rattus norvegicus assay, from the lowest: compound 3; then compound 2; then compound 1.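

In the Rattus norvegicus assay, hydrogen in place of methoxy next to the ring nitrogen gives a number 14 percentage points lower from compound 2 to compound 3 (beyond the scatter), with compound 2 at 50% and compound 3 at 36% in this reading, so the methoxy position affects this reading and removing the group does not raise it. Also in the Rattus norvegicus assay, moving the trifluoromethyl group on the phenyl ring gives a number 48 percentage points lower from compound 1 to compound 3 (beyond the scatter), a large step at a second site on the sulfonyl side. In a physicochemical assay for solubility, read by HPLC (on this read-out lower numbers stand for lower solubility and higher numbers for higher solubility), the methoxy change gives a 1.7-fold lower number from compound 2 to compound 3 (0.23 log units; within the scatter), which lies within the scatter, with compound 2 at 7340 ug/mL and compound 3 at 4280 ug/mL on this read-out. Nothing here gives a cause for either stability step.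

Open, going by these compounds, is how an amine or a longer alkoxy chain at this aromatic carbon would read in the Rattus norvegicus assay, and whether methoxy behaves the same alongside 3-(trifluoromethyl)phenyl.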